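This account rests on a few compounds, and the source may have more. Where it says the series, first, only, none or still open, it means among the compounds named here.

Compound 1 `CCCc1nnc(SCC(=O)c2ccc(C)cc2)n1N1C(=O)c2ccccc2C1=O`: > 200000 nM
Compound 2 `COc1cc(-c2nnc(SCc3ccccc3Cl)n2N2C(=O)c3ccccc3C2=O)cc(OC)c1OC`: > 200000 nM

In a functional assay on MKN-45 cells (Homo sapiens) for cytotoxicity, read by MTT assay, with a stated time of 48 h (a higher number here means a weaker inhibitor, a lower number a stronger inhibitor), compound 2 gives only a limit of the assay, > 200000 nM. Compound 1 likewise gives only a limit, > 200000 nM. The same bound holds for the two values shown (the limit of > 200000 nM in this assay, at which 2 of the 2 values shown sit). Compound 3 `COc1cc(-c2nnc(SCC(=O)c3ccc(C)cc3)n2N2C(=O)c3ccccc3C2=O)cc(OC)c1OC` differs from compound 2 by (4-methylphenyl)carbonyl in place of 2-chlorophenyl on a saturated chain carbon bound to a sulfur, the side chain carried by compound 1. Among the measured compounds shown here, no step between measured compounds is available; with both at the bound, no step beyond the scatter is expected in this assay, a number no higher from compound 2 to compound 3 (the limit leaves the size open). Compound 3 is expected at 200000 nM, with a range from 50000 nM to 400000 nM, most likely reported again as a limit.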

Compound 3, half-maximal inhibitory concentration: 9620 nM
Estimate against measurement, compound 3: 21-fold (1.32 log units) above; the measured number lies below the stated range.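

Working notes: in this assay, (4-methylphenyl)carbonyl in place of 2-chlorophenyl on a saturated chain carbon bound to a sulfur gives an at least 20-fold lower number from compound 2 to compound 3 (1.31 log units; beyond the scatter). With that side chain held, 3,4,5-trimethoxyphenyl in place of propyl on an aromatic carbon gives an at least 20-fold lower number from compound 1 to compound 3 (1.31 log units; beyond the scatter). Among these three compounds, therefore, a value clear of the limit appears only where the side chain and the 3,4,5-trimethoxyphenyl group occur together, in compound 3.

The compounds shown do not separate the part played by the carbonyl from that of the 4-methylphenyl ring. As far as these compounds go, whether an amine or a carboxylic acid in place of 3,4,5-trimethoxyphenyl would keep such a number remains open.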